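Permeability in the series: from compound 1 toward compound 3

The source may hold more compounds than are shown below. What is called first, only, known or untested is meant among the compounds shown, and "the series" means these compounds.

Within the data shown here, compound 1 `COc1ccc(F)cc1CNCCCNc1ccnc2cc(Cc3cc(C)cc(C)c3)ccc12` stands lowest of the two numbers so far in an ADME assay for permeability, using PAMPA, with a stated time of 30 min, at pH 7.4; on this read-out higher numbers stand for higher permeability and lower numbers for lower permeability: compound 1 gives 23 10^-6 cm/s. Among the measured compounds shown here, compound 2 `COc1ccc(Oc2ccc3c(NCCCNCc4cccc(OC)c4O)ccnc3c2)cc1` in this assay gives 317 10^-6 cm/s, a gap beyond the scatter, but the two differ in many places and no single step is defined between them. Compound 3 `COc1ccc(F)cc1CNCCCNc1ccnc2cc(CC(C)C)ccc12` differs from compound 1 by isopropyl in place of 3,5-dimethylphenyl on a saturated chain carbon bound to an aromatic carbon. For the measured compounds named here, no measured pair shows this change, so the expected step of a 1.2-fold lower number from compound 1 to compound 3 (0.06 log units; within the scatter) is small, with no direction beyond the scatter. Compound 3 is estimated at 20 10^-6 cm/s, expected within 7 10^-6 cm/s to 60 10^-6 cm/s.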

Compound 3, apparent permeability: 23 10^-6 cm/s
Estimate against measurement, compound 3: 1.2-fold (0.06 log units) below, within the range that was stated.
By their numbers in this assay, from the lowest: compounds 1 and 3 (each within the scatter of the next); then compound 2.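

In this assay, among these compounds, isopropyl in place of 3,5-dimethylphenyl on a saturated chain carbon bound to an aromatic carbon gives no change at the digits printed from compound 1 to compound 3 (within the scatter), the first single-place step. At this place, then, the six-membered aromatic ring of carbon only can be given up without a shift beyond the scatter. Nothing at hand gives a reason for this result. Going by these compounds, both groups compared carry no net charge and no hydrogen-bond donors or acceptors, so an amine or a carboxylic acid at this place remains open, as does a longer chain. On these data alone, whether the step reads the same on the core of compound 2 also stays open.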